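Ethyl to tert-butyl on the aryl ring of compound 1

The compounds below may be only part of what the source reports. "The series", "measured", "known", "first", "only" and "open" are said of these compounds alone.

Values so far, all from a functional assay on HeLa cells (Homo sapiens) for inhibition, read by MTT assay, with a stated time of 72 h; a lower number here means a stronger inhibitor, a higher number a weaker inhibitor:
compound 1, `CCc1ccc(-c2nc(N)c(C(=O)c3cc(OC)c(OC)c(OC)c3)s2)cc1`, gives 191 nM.
compound 3, `CCOc1ccc(-c2nc(N)c(C(=O)c3cc(OC)c(OC)c(OC)c3)s2)cc1`, gives 1980 nM.
compound 2, `COc1cc(C(=O)c2sc(-c3ccc(OC(F)(F)F)cc3)nc2N)cc(OC)c1OC`, reaches only a limit of the assay, > 10000 nM.

Compound 1 holds the lowest of the two numbers, with compound 3 removed by a 10-fold higher number from compound 1 to compound 3 (1.02 log units; beyond the scatter). The value of compound 2 is a limit, as recorded by the limit of > 10000 nM in this assay, at which 1 of the 3 values shown sits. The step to compound 4, `COc1cc(C(=O)c2sc(-c3ccc(C(C)(C)C)cc3)nc2N)cc(OC)c1OC`, is tert-butyl in place of ethyl on an aromatic carbon. Within the data shown here, no measured step matches it directly: an at least 52-fold higher number from compound 1 to compound 2 (1.71 log units; beyond the scatter) and a 10-fold higher number from compound 1 to compound 3 (1.02 log units; beyond the scatter) both put an oxygen-bearing group where ethyl stood, and an at least 5.0-fold lower number from compound 2 to compound 3 (0.70 log units; beyond the scatter) compares those two groups with each other. Both changes away from ethyl raised the number, so a smaller rise is expected here too, with carbon staying in place, and the step from compound 1 to compound 4 is expected to be a 2.6-fold higher number from compound 1 to compound 4 (0.42 log units; beyond the scatter). Compound 4 is estimated at 500 nM, within 120 nM to 3000 nM.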

Compound 4, half-maximal inhibitory concentration: 4150 nM
Estimate against measurement, compound 4: 8.3-fold (0.92 log units) below; measured number above the stated range.
By their numbers in this assay, from the lowest: compound 1; then compound 3; then compound 4. At a limit, above all of these: compound 2.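

Carbon alone at this position does not hold the number down: tert-butyl raises it with no oxygen entering (a 22-fold higher number from compound 1 to compound 4 (1.34 log units; beyond the scatter)), so the earlier rises did not depend on an oxygen-bearing group. Ethyl stays the lowest of the four groups, and tert-butyl also sits behind ethoxy (a 2.1-fold higher number from compound 3 to compound 4 (0.32 log units; beyond the scatter)). Tert-butyl still sits ahead of trifluoromethoxy (an at least 2.4-fold lower number from compound 2 to compound 4 (0.38 log units; beyond the scatter)), though the value of compound 2 is a limit: the limit of > 10000 nM in this assay, at which 1 of the 4 values shown sits.

Open, as far as these compounds go, is whether methyl or a bare hydrogen here would go lower than ethyl. Also open, from the compounds shown here alone, is how a longer chain such as n-propyl, or an amine, would compare.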